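Methoxy for Methyl on the Aryl Ketone of Compound 3

A few compounds are considered here, and "the series" means these few. Any claim that something is new, unique, unknown or untested is made for them only; others in the source may bear on it.

Compound 1 `COc1ccc(C(=O)/C=C/c2cc(-c3cc(OC)c(OC)c(OC)c3)n3nc(-c4ccccc4)cc3n2)cc1` gives 79800 nM in an ADME assay on HEK293 cells (Homo sapiens) for antiproliferative activity, read by MTT assay, with a stated time of 24 h; on this read-out higher numbers stand for weaker inhibition and lower numbers for stronger inhibition.
Compound 2 `COc1ccc(-c2cc(C(=O)/C=C/c3ccc(Cl)cc3)nc3cc(-c4ccccc4)nn23)cc1OC` gives 39100 nM in this assay.
Compound 3 `COc1ccc(-c2cc(/C=C/C(=O)c3ccc(C)cc3)nc3cc(-c4ccccc4)nn23)cc1OC` gives 62600 nM in this assay.

Of the three numbers, that of compound 3 lies in the middle, yet its gaps to compound 1 and to compound 2 are both within the usual scatter, so the three compounds cannot be ranked against one another on this evidence.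

Compound 4 `COc1ccc(C(=O)/C=C/c2cc(-c3ccc(OC)c(OC)c3)n3nc(-c4ccccc4)cc3n2)cc1` differs from compound 3 by methoxy in place of methyl on an aromatic carbon. For the measured compounds named here, only one measured step touches the same region of the molecule: a 1.6-fold higher number from compound 2 to compound 3 (0.20 log units; within the scatter), which exchanged the whole aryl-ketone arm for a reversed one and still stayed within the scatter. Going by the values given here, no pair among the measured compounds shows a methyl replaced by a methoxy directly. Compound 4 carries the same methoxyphenyl ketone as compound 1, there on a differently substituted core; compound 1 gives 79800 nM, a number that again sits within the scatter of compound 3.

Given that the one relevant step was flat, the step from compound 3 to compound 4 is expected to be a 1.0-fold higher number from compound 3 to compound 4 (0.02 log units; within the scatter), that is, no change beyond the scatter. Compound 4 is therefore estimated at 65000 nM, with a range from 25000 nM to 160000 nM.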

Compound 4, half-maximal inhibitory concentration: 40000 nM
Compound 4: middle estimate off by 1.6-fold (0.21 log units), on the high side; low and high end bracket the measured number.
By their numbers in this assay, from the lowest: compounds 2, 4, 3 and 1 (each within the scatter of the next, the first and the last beyond it).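

For the compounds shown here, the first direct exchange of methyl for methoxy at this place, on an aromatic carbon of the aryl ketone para to a large group, gives a 1.6-fold lower number from compound 3 to compound 4 (0.19 log units; within the scatter) in this assay and shows that this position takes either group with no change that can be told from the scatter. Two further single changes lead to compound 4 and read the same way: exchanging the whole arm for 2-((4-methoxyphenyl)carbonyl)ethenyl gives a 1.0-fold higher number from compound 2 to compound 4 (0.01 log units; within the scatter) and putting hydrogen in place of a methoxy on an aromatic carbon gives a 2.0-fold lower number from compound 1 to compound 4 (0.30 log units; within the scatter) so that neither the arm nor this methoxy separates these compounds here. No measurement at hand speaks to what lies behind these flat steps.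

As far as these compounds go, the two groups compared at this place are methyl and methoxy alone, so it stays open whether an amine, a carboxylic acid or a longer chain there would move the number beyond the scatter. From the compounds shown here alone, it also stays open whether the flat result holds on a differently substituted core, since the methyl and methoxy pair is read only once, on the core of compound 3.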